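The source may hold more compounds than are shown below. What is called first, only, known or untested is meant among the compounds shown, and "the series" means these compounds.

Measured compounds in a functional assay on SK-MEL-28 cells (Homo sapiens) for inhibition, read by sulforhodamine B assay, with a stated time of 48 h; a lower number here means that less compound is tolerated, a higher number that more compound is tolerated:
compound 1 `COc1cc(-c2nn(-c3cccc(NC(=O)Nc4cc(C(F)(F)F)cc(C(F)(F)F)c4)c3)cc2-c2ccncc2)ccc1Cl`, 3380 nM
compound 2 `COc1cc(-c2nn(-c3cccc(NC(=O)Nc4ccc(Cl)c(Cl)c4)c3)cc2-c2ccncc2)ccc1Cl`, > 50000 nM
compound 3 `O=C(Nc1cccc(-n2cc(-c3ccncc3)c(-c3ccc(Cl)c(O)c3)n2)c1)Nc1ccc(Cl)c(Cl)c1`, > 32500 nM

In this assay, for the measured compounds named here, compound 1 gives 3380 nM, the only number among the three. For compound 2 the result is a limit of the assay, > 50000 nM. For compound 3 the result is likewise a limit, > 32500 nM. The difference between the core of compound 1 and that of compound 2 is not broken down here. Compound 3 arises from compound 2 by hydrogen in place of methyl on an oxygen on an aromatic ring, and the step that the two limits leave unreadable from compound 2 to compound 3 cannot be sized, since both ends sit at limits the limit of > 50000 nM in this assay, at which 1 of the 3 values shown sits, and (the limit of > 32500 nM in this assay, at which 1 of the 3 values shown sits). Compound 4 `O=C(Nc1cccc(-n2cc(-c3ccncc3)c(-c3ccc(Cl)c(O)c3)n2)c1)Nc1cc(C(F)(F)F)cc(C(F)(F)F)c1` arises from compound 1 by the same change, (hydrogen in place of methyl on an oxygen on an aromatic ring). With no readable precedent for this change, compound 4 is expected near compound 1, with the step of a 1.8-fold higher number from compound 1 to compound 4 (0.25 log units; within the scatter) estimated. Compound 4 is therefore estimated at 6000 nM, between 1800 nM and 30000 nM.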

Compound 4, concentration lethal to 50% of the cells: 3090 nM
Compound 4: middle estimate off by 1.9-fold (0.29 log units), on the high side; the range from low to high includes it.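

In this assay, going from methoxy to hydroxy gives a 1.1-fold lower number from compound 1 to compound 4 (0.04 log units; within the scatter), so on this core the change leaves the two compounds level. The same change on the core of compound 2 cannot be sized, as both of its ends are limits of the assay and not numbers. The series therefore offers one readable case, which does not show that the change carries from one core to another.

The compounds shown leave open how this assay would read with an ethyl or a longer chain on that oxygen, or with an amine in place of the hydroxy. They also leave open how the methoxy to hydroxy change reads on a further core where both ends give numbers.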